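Mirror-image pair at the assay limit: compound 1 to 4

This account rests on a few compounds, and the source may have more. Where it says the series, first, only, none or still open, it means among the compounds named here.

Measured so far:
compound 1 `O=[N+]([O-])c1ccc(NC(=S)NCCNS(=O)(=O)c2ccc(-c3ccccc3O[C@H]3CC[C@@H](O)CC3)s2)cc1` gives > 50000 nM
compound 2 `Nc1ccc(Oc2ccccc2-c2ccc(S(=O)(=O)NCCNC(=O)Nc3ccc(Cl)cc3)s2)cc1` gives > 50000 nM
compound 3 `COc1ccc(Oc2ccccc2-c2ccsc2S(=O)(=O)N2CCN(C(=S)Nc3ccc([N+](=O)[O-])cc3)CC2)cc1OC` gives > 50000 nM

In a functional assay on HL-60 cells (Homo sapiens) for inhibition, read by CCK-8 assay, with a stated time of 48 h (on this read-out higher numbers stand for weaker inhibition and lower numbers for stronger inhibition), compound 1 gives > 50000 nM, which is a limit of the assay and not a number. Compound 2 likewise gives only a limit in this assay. Compound 3 also gives only a limit in this assay. Within the data shown here, all three values shown therefore sit at the limit of > 50000 nM in this assay, at which 3 of the 3 values shown sit, so compound 1 cannot be placed above or below the others, and no step between measured compounds is available.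

Compound 4 `O=[N+]([O-])c1ccc(NC(=S)NCCNS(=O)(=O)c2ccc(-c3ccccc3O[C@H]3CC[C@H](O)CC3)s2)cc1` differs from compound 1 as follows: the two compounds have the same atoms and bonds and differ only in configuration as drawn: 2 of 2 stereo elements differ (all stereocentres are inverted: mirror images); a stereocentre at a saturated ring carbon is drawn s in compound 1 and r in compound 4; a stereocentre at a saturated ring carbon is drawn s in compound 1 and r in compound 4. Among the measured compounds shown here, no measured pair here shows what inversion of both stereocentres does in this assay. The expected step is a step that the limit leaves unreadable from compound 1 to compound 4, none beyond the usual scatter. For compound 4 the expected value is 80000 nM, estimated between 30000 nM and 300000 nM.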

Compound 4, half-maximal inhibitory concentration: 11600 nM
Beside the measured number, compound 4's estimate is 6.9-fold (0.84 log units) above it; the measured number lies below the stated range.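

In this assay, inverting both stereocentres at the saturated ring carbons gives an at least 4.3-fold lower number from compound 1 to compound 4 (0.63 log units; beyond the scatter). The value of compound 1, > 50000 nM, is a limit of the assay and not a number. Configuration alone is enough to move this read-out to a measurable value: the fact that compounds 1 and 4 differ only in the configuration as drawn

As far as these compounds go, both stereocentres change together, so which of them carries the step stays open, as does its full size. Also open, from the compounds shown here alone, is whether a carboxylic acid in place of the hydroxyl on the saturated ring would preserve the activity of compound 4.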